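Swapping pentan-3-yl for 4-cyanobenzyl: an expected permeability

The source may report more compounds than this note shows. Statements on the series, on what has been measured and on what is new or still open speak of the compounds shown alone.

Of the compounds shown here, three sharing one core have been measured in an ADME assay for permeability, using PAMPA, with a stated time of 30 min, at pH 7.4; a higher number here means that the compound crosses the layer faster, a lower number that the compound crosses the layer more slowly. Compound 1 `c1ccc(-c2ccc3c(NCCCNCc4ccco4)ccnc3c2)cc1` gives 237 10^-6 cm/s, compound 2 `Fc1ccc(Cc2ccc3c(NCCCNCc4ccco4)ccnc3c2)cc1` gives 23 10^-6 cm/s, and compound 3 `CCC(CC)c1ccc2c(NCCCNCc3ccco3)ccnc2c1` gives 23 10^-6 cm/s. Compound 3 therefore sits level with compound 2, the two together at the low end of the three numbers, since no change at the digits printed from compound 2 to compound 3 (within the scatter), while a 10-fold lower number from compound 1 to compound 3 (1.01 log units; beyond the scatter). Compound 4 `N#Cc1ccc(Cc2ccc3c(NCCCNCc4ccco4)ccnc3c2)cc1` differs from compound 3 by 4-cyanobenzyl in place of pentan-3-yl on an aromatic carbon. Among the measured compounds shown here, the nearest precedent is a 10-fold lower number from compound 1 to compound 2 (1.01 log units; beyond the scatter), the same size as a 10-fold lower number from compound 1 to compound 3 (1.01 log units; beyond the scatter), so in this assay an exchange of one benzyl-type group for another is expected to move the number little beyond the scatter, if anything slightly downward. Compound 4 is accordingly estimated at 15 10^-6 cm/s, between 5 10^-6 cm/s and 45 10^-6 cm/s, which means a 1.5-fold lower number from compound 3 to compound 4 (0.19 log units; within the scatter).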

Compound 4, apparent permeability: 23 10^-6 cm/s
For compound 4 the middle estimate is 1.5-fold (0.19 log units) below the measured one; the measured number falls inside the stated range.
By their numbers in this assay, from the lowest: compounds 2, 3 and 4 (each within the scatter of the next); then compound 1.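

In this assay the para substituent on the benzyl group shows no effect at this aromatic carbon, as cyano in place of fluoro gives no change at the digits printed from compound 2 to compound 4 (within the scatter) and the wider exchange for pentan-3-yl gives no change at the digits printed from compound 3 to compound 4 (within the scatter) here too. The phenyl group alone stands apart, with a 10-fold lower number from compound 1 to compound 4 (1.01 log units; beyond the scatter) repeating the large step already seen for the other two groups. Nothing shown accounts for these numbers.

Still open, from the compounds shown here alone, is whether an amine or a carboxylic acid on the benzyl group, or a longer chain in place of pentan-3-yl, would stay at this level. Also open, going by these compounds, is whether any group other than phenyl reaches the number of compound 1.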